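Urea to aryl ketone switch on the shared core

The compounds below may be only part of what the source reports. "The series", "measured", "known", "first", "only" and "open" are said of these compounds alone.

Compound 1, `COc1cc(-c2nn(-c3cccc(NC(=O)c4cccc(C(F)(F)F)c4)c3)cc2-c2ccncc2)ccc1Cl`: in a functional assay on NCI/ADR-RES cells (Homo sapiens) for inhibition, read by sulforhodamine B assay, with a stated time of 48 h (a higher number here means a weaker inhibitor of growth, a lower number a stronger inhibitor of growth), compound 1 gives 3170 nM.
Compound 2, `COc1cc(-c2nn(-c3cccc(NC(=O)Nc4ccc(Cl)c(Cl)c4)c3)cc2-c2ccncc2)ccc1Cl`: compound 2 gives 4670 nM.
Compound 3, `COc1cc(-c2nn(-c3cccc(NC(=O)Nc4cccc(C(F)(F)F)c4)c3)cc2-c2ccncc2)ccc1Cl`: compound 3 gives 3640 nM.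

Among these three numbers, compound 3 holds the second highest place. Its nearest neighbour is compound 1, a 1.1-fold higher number from compound 1 to compound 3 (0.06 log units; within the scatter), and its furthest is compound 2, a 1.3-fold lower number from compound 2 to compound 3 (0.11 log units; within the scatter); all three compounds therefore sit within the scatter of one another, and no order among them can be claimed.

Compound 4, `COc1cc(-c2nn(-c3cccc(NC(=O)c4ccc(Cl)c(C(F)(F)F)c4)c3)cc2-c2ccncc2)ccc1Cl`, has not yet been measured. It differs from compound 3 in one place: 4-chloro-3-(trifluoromethyl)phenyl in place of (3-(trifluoromethyl)phenyl)amino on a carbonyl carbon. Among the measured compounds shown here, the measured step that bears most directly on this change is the one from compound 1 to compound 3, which runs the opposite way on the same carbonyl carbon and gave a 1.1-fold higher number from compound 1 to compound 3 (0.06 log units; within the scatter). The step from compound 1 to compound 2, a 1.5-fold higher number from compound 1 to compound 2 (0.17 log units; within the scatter), shows that exchanging one aryl pattern for another at this end of the molecule also stayed within the scatter. For the measured compounds named here, no measured compound carries the 4-chloro-3-(trifluoromethyl)phenyl group itself.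

On this basis compound 4 is expected to show a step of a 1.2-fold lower number from compound 3 to compound 4 (0.08 log units; within the scatter), that is, no change beyond the scatter. Compound 4 is therefore estimated at 3000 nM, with a range from 1500 nM to 6000 nM.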

Compound 4, concentration for total growth inhibition: 11200 nM
Estimate against measurement, compound 4: 3.7-fold (0.57 log units) below; measured number outside the range, above it.
By their numbers in this assay, from the lowest: compounds 1, 3 and 2 (each within the scatter of the next); then compound 4.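

Among the compounds shown here, until this result, every exchange on the carbonyl carbon had stayed within the scatter in this assay, but the 4-chloro-3-(trifluoromethyl)phenyl group gives changes beyond it, with a 3.1-fold higher number from compound 3 to compound 4 (0.49 log units; beyond the scatter) and a 2.4-fold higher number from compound 2 to compound 4 (0.38 log units; beyond the scatter), both toward weaker inhibition of growth. The most direct reading is a 3.5-fold higher number from compound 1 to compound 4 (0.55 log units; beyond the scatter): only one added chloro on the aryl group separates this pair, and compound 1 sits within the scatter of compound 3, so losing the amide-type nitrogen does not by itself produce the change, while compound 2 goes against any general rule about chloro, as it carries chloro groups on its aryl ring and stays within the scatter of compound 1 and compound 3. Nothing available gives a measured reason for this loss of growth inhibition.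

The compounds shown leave open whether a fluoro, methyl or methoxy group in place of this chloro would give the same step. For the compounds shown here, they also leave open whether (4-chloro-3-(trifluoromethyl)phenyl)amino on the same carbonyl carbon would behave as the aryl group does, since the added chloro is seen on only one side of that exchange.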